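Swapping Thiophen-2-yl for 2,4-Dichlorophenyl on the Amide Carbonyl

This account rests on a few compounds, and the source may have more. Where it says the series, first, only, none or still open, it means among the compounds named here.

Compound 1, `COc1cc(/C=C/C(=O)c2cccc(NC(=O)c3ccccc3)c2)ccc1O`, gives 3.47 ug/mL in a functional assay on Vero cells (Chlorocebus sabaeus) for inhibition; a higher number here means a weaker inhibitor, a lower number a stronger inhibitor. Compound 2, `COc1cc(/C=C/C(=O)c2cccc(NC(=O)c3cc(Cl)cc(Cl)c3)c2)ccc1O`, reaches only a limit of this assay, > 50 ug/mL. Compound 3, `COc1cc(/C=C/C(=O)c2cccc(NC(=O)c3cccs3)c2)ccc1O`, gives 3.98 ug/mL in this assay.

Compound 3 holds the highest of the two numbers, with compound 1 beside it: a 1.1-fold higher number from compound 1 to compound 3 (0.06 log units; within the scatter). Going by the values given here, compound 4, `COc1cc(/C=C/C(=O)c2cccc(NC(=O)c3ccc(Cl)cc3Cl)c2)ccc1O`, differs from compound 3 as follows. 2,4-dichlorophenyl in place of thiophen-2-yl on a carbonyl carbon The steps that bear on this change are an at least 14-fold higher number from compound 1 to compound 2 (1.15 log units; beyond the scatter) and an at least 12-fold lower number from compound 2 to compound 3 (1.09 log units; beyond the scatter), both large, and compound 2 sits at the limit of > 50 ug/mL in this assay, at which 1 of the 3 values shown sits. A dichlorophenyl entering on the carbonyl carbon is therefore expected to bring a large rise, a 6.3-fold higher number from compound 3 to compound 4 (0.80 log units; beyond the scatter), with a real chance that only a limit is returned. Compound 4 is estimated at 25 ug/mL, within 6 ug/mL to 60 ug/mL.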

Compound 4, half-maximal inhibitory concentration: 27.2 ug/mL
Beside the measured number, compound 4's estimate is 1.1-fold (0.04 log units) below it; the measured number falls inside the stated range.
By their numbers in this assay, from the lowest: compounds 1 and 3 (each within the scatter of the next); then compound 4. At a limit, above all of these: compound 2.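

In this assay, a dichlorophenyl group on the carbonyl carbon now gives a measured number rather than a limit, and the 2,4-dichlorophenyl group still weakens inhibition relative to both thiophen-2-yl and phenyl: a 6.8-fold higher number from compound 3 to compound 4 (0.83 log units; beyond the scatter), and a 7.8-fold higher number from compound 1 to compound 4 (0.89 log units; beyond the scatter). Compound 2 gives only a limit, > 50 ug/mL. The comparison of the two dichlorophenyl groups is therefore a floor, an at least 1.8-fold lower number from compound 2 to compound 4 (0.26 log units; that floor lies within the scatter), and it does not rank them. Open, on these data alone, is how a phenyl carrying a dimethylamino group or a carboxylic acid would behave, and whether a single chlorine is enough for the rise.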